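The source may report more compounds than this note shows. Statements on the series, on what has been measured and on what is new or still open speak of the compounds shown alone.

Working notes on the series.

Compound 3 `COCCNC(=C\C(=O)/C=C/c1ccc(O)c(OC)c1)/C=C/c1ccc(O)c(OC)c1` and compound 1 `COc1cc(/C=C/C(=O)/C=C(/C=C/c2ccc(O)c(OC)c2)NCCO)ccc1O` share a core and differ in one place only: hydrogen in place of methyl on an oxygen on a saturated carbon. In an ADME assay on CHO-K1 cells (Cricetulus griseus) for activation, read by fluorescence, tested at 1 uM (on this read-out higher numbers stand for a weaker effect at the one concentration tested and lower numbers for a stronger effect), compound 3 gives 94%, and compound 1 gives 93.5%, so that the step of a number 0.5 percentage points lower from compound 3 to compound 1 (within the scatter). Compound 2 `COCCNC(=C\C(=O)/C=C/c1ccc(O)cc1)/C=C/c1ccc(O)cc1` rests on a different core; the difference between the cores of compound 2 and compound 3 is not broken down here. In this assay compound 2 gives 82.5%, which is the lowest of the three numbers and sits beyond the scatter from both compound 1 and compound 3.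

Compound 4 `O=C(/C=C(/C=C/c1ccc(O)cc1)NCCO)/C=C/c1ccc(O)cc1` has not been measured. It differs from compound 2 by hydrogen in place of methyl on an oxygen on a saturated carbon, the same change that separates compound 3 from compound 1, and the place of the change reads the same in both pairs. The change occurs twice among the compounds shown, once measured and once open. Within the data shown here, its one measured instance left the read-out within the scatter. Among the measured compounds shown here, the step from compound 2 to compound 4 in this assay is therefore expected to be no change at the digits printed from compound 2 to compound 4 (within the scatter), close to no step, because a number 0.5 percentage points lower from compound 3 to compound 1 (within the scatter). This expectation rests on a single pair on a different core, so a wide spread is kept. Compound 4 is estimated at 82.5%, with an expected range from 72% to 92%.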

Compound 4, a percentage reported as activity, at one concentration (the size of the read-out at that concentration, not a potency): 93.4%
For compound 4 the middle estimate is 10.9 percentage points below the measured one; the whole stated range lies below it.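

In this assay, replacing 2-methoxyethyl with 2-hydroxyethyl on the core of compound 2 gives a number 10.9 percentage points higher from compound 2 to compound 4 (beyond the scatter), and, although this step and the earlier one read differently against the scatter when taken singly, the two cannot be told apart when set side by side: the same change on two cores in this assay, a number 0.5 percentage points lower (within the scatter) from compound 3 to compound 1 and a number 10.9 percentage points higher (beyond the scatter) from compound 2 to compound 4, 11.4 percentage points apart, within the scatter of two such steps

The two pairs therefore give no ground for saying that the core changes what this replacement does, but they also do not establish that the step carries from one core to another unchanged, since the gap between the steps is large and only its scatter keeps it from being read as a difference. With one pair on each of two cores, the size of the step on any further core stays unsettled, and no rule for the series can be drawn from these compounds.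

The compounds shown carry only 2-methoxyethyl and 2-hydroxyethyl at the place of the change, so how a longer chain, an amine or a carboxylic acid would read in this assay remains open. Also open, on these data alone, is whether repeated readings of these pairs, or a third core carrying the same replacement, would separate the two steps.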